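Urea heteroaryl rearrangement: compound 3 to compound 4

A few compounds are considered here, and "the series" means these few. Any claim that something is new, unique, unknown or untested is made for them only; others in the source may bear on it.

Measured in an assay on isolated protein for inhibition of Fatty-acid amide hydrolase 1 (Rattus norvegicus), with a stated time of 60 min; on this read-out lower numbers stand for stronger inhibition and higher numbers for weaker inhibition:
compound 1 `O=C(Nc1noc2cnccc12)N1CCN(Cc2cccc(Oc3ccc(Cl)cc3)c2)CC1` gives 0.7 nM
compound 2 `O=C(Nc1noc2cccnc12)N1CCN(Cc2cccc(Oc3ccc(Cl)cc3)c2)CC1` gives 22 nM
compound 3 `O=C(Nc1cccn2ccnc12)N1CCN(Cc2cccc(Oc3ccc(Cl)cc3)c2)CC1` gives 3500 nM

In this assay compound 3 stands highest of the three, separated from the rest by a 160-fold higher number from compound 2 to compound 3 (2.20 log units; beyond the scatter) and a 5000-fold higher number from compound 1 to compound 3 (3.70 log units; beyond the scatter). Compound 4 `O=C(Nc1cccc2nccn12)N1CCN(Cc2cccc(Oc3ccc(Cl)cc3)c2)CC1` differs from it by a group of 9 heavy atoms (7 carbon, 2 nitrogen; one five-membered aromatic ring with 2 hetero atoms, one six-membered aromatic ring with 1 hetero atom) in place of a group of 9 heavy atoms (7 carbon, 2 nitrogen; one five-membered aromatic ring with 2 hetero atoms, one six-membered aromatic ring with 1 hetero atom), on an amide-type nitrogen. For the measured compounds named here, no measured step covers such a rearrangement of this carbon-and-nitrogen bicycle. The steps that do alter the group on the urea nitrogen, a 31-fold higher number from compound 1 to compound 2 (1.50 log units; beyond the scatter) and a 160-fold higher number from compound 2 to compound 3 (2.20 log units; beyond the scatter), show that this part of the molecule moves the read-out strongly, so a large step in either direction is plausible and the estimate is held loosely. For compound 4 the expected step is a 1.4-fold lower number from compound 3 to compound 4 (0.15 log units; within the scatter). Compound 4 is estimated at 2500 nM, in the range 300 nM to 20000 nM.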

Compound 4, half-maximal inhibitory concentration: 5.7 nM
Compound 4: middle estimate off by 440-fold (2.64 log units), on the high side, and the stated range ends above it.
By their numbers in this assay, from the lowest: compound 1; then compound 4; then compound 2; then compound 3.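

In this assay, joining the same atoms differently on an amide-type nitrogen gives a 610-fold lower number from compound 3 to compound 4 (2.79 log units; beyond the scatter), so at this position the read-out depends on the arrangement of the group and not only on its atom content. The group without oxygen is not confined to high numbers, as a 3.9-fold lower number from compound 2 to compound 4 (0.59 log units; beyond the scatter) and an 8.1-fold higher number from compound 1 to compound 4 (0.91 log units; beyond the scatter) place compound 4 among the two oxygen-containing compounds. No measurement shown bears on what lies behind these steps. Going by these compounds, it remains open whether a methyl or an amine added to the group in compound 4 would keep its low number.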